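Dichlorobenzyl Ether Follows a Weak Fluorobenzyl Analogue

This account rests on a few compounds, and the source may have more. Where it says the series, first, only, none or still open, it means among the compounds named here.

Compound 2 `Cc1ccc(NC(=O)NC(=O)c2ccc(OCc3cccc(F)c3)cc2)cc1-c1nc2ccccc2[nH]1` is the weaker of the two measured compounds in a functional assay on MNK45 cells (Homo sapiens) for inhibition, read by MTT assay, with a stated time of 48 h (a higher number here means a weaker inhibitor, a lower number a stronger inhibitor), where compound 2 gives 53000 nM. Among the compounds with values here, its only measured neighbour, compound 1 `Cc1ccc(NC(=O)NC(=O)c2ccc(OCc3ccccc3F)cc2)cc1-c1nc2ccccc2[nH]1`, differs from it solely in the fluorine position on the benzyl ether, and in this assay compound 1 gives 1830 nM; the step of a 29-fold higher number from compound 1 to compound 2 (1.46 log units; beyond the scatter) shows how strongly that single change mattered.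

Compound 3 `Cc1ccc(NC(=O)NC(=O)c2ccc(OCc3ccc(Cl)cc3Cl)cc2)cc1-c1nc2ccccc2[nH]1` is the next analogue, and it differs from compound 2 by 2,4-dichlorophenyl in place of 3-fluorophenyl on a saturated chain carbon bound to an oxygen on an aromatic ring. Within the data shown here, no step between measured compounds covers this exact change. Among the measured compounds shown here, the only step that bears on it is a 29-fold higher number from compound 1 to compound 2 (1.46 log units; beyond the scatter), which shows that the substitution pattern on this ring can move the number a long way, and that the 2-fluorophenyl of compound 1 sits far below the 3-fluorophenyl of compound 2. Since compound 3 again carries a substituent at the 2-position, a lower number than compound 2 is expected, with a step of an 8.8-fold lower number from compound 2 to compound 3 (0.95 log units; beyond the scatter). Compound 3 is therefore estimated at 6000 nM, with a range from 1000 nM to 35000 nM.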

Compound 3, half-maximal inhibitory concentration: 2550 nM
For compound 3 the middle estimate is 2.4-fold (0.37 log units) above the measured one; low and high end bracket the measured number.
By their numbers in this assay, from the lowest: compounds 1 and 3 (each within the scatter of the next); then compound 2.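

In this assay, the change to 2,4-dichlorophenyl gives a 21-fold lower number from compound 2 to compound 3 (1.32 log units; beyond the scatter), so the high number of compound 2 is not a general feature of a substituted phenyl on this saturated chain carbon bound to an oxygen on an aromatic ring. The change from the 2-fluorophenyl gives a 1.4-fold higher number from compound 1 to compound 3 (0.14 log units; within the scatter), which means that these two rings cannot be told apart here, despite their different halogens, and compound 2, with its 3-fluorophenyl, is the weakest of the three. Nothing available explains why the 3-fluorophenyl stands apart from the other two rings.

Because the step to compound 3 changes both the halogen and the substitution pattern, these compounds cannot show which of the two accounts for the lower number, and a 3-chlorophenyl or a 2-chlorophenyl would be needed to separate them. As far as these compounds go, it also remains open how an unsubstituted phenyl, a ring carrying a methoxy group or an amine, or a longer chain in place of the benzyl carbon would behave in this assay.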